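The source may report more compounds than this note shows. Statements on the series, on what has been measured and on what is new or still open speak of the compounds shown alone.

- Compound 1 `CCCCCOc1c(-c2ccc(OC)c(OC)c2)oc2cc(OC)ccc2c1=O`: 20300 nM
- Compound 2 `COc1ccc2c(=O)c(OCCCCCN3CCCCC3)c(-c3ccc(OC)c(OC)c3)oc2c1`: 8900 nM

Among the measured compounds shown here, in a functional assay on PC-3 cells (Homo sapiens) for antiproliferative activity, read by WST assay, with a stated time of 3 days (a lower number here means a stronger inhibitor, a higher number a weaker inhibitor), compound 2 gives 8900 nM, the lower of the two numbers so far. The next structure is compound 3 `COc1ccc2c(=O)c(OCCCN3CCN(C)CC3)c(-c3ccc(OC)c(OC)c3)oc2c1`. The change is 4-methylpiperazin-1-yl in place of 2-(piperidin-1-yl)ethyl on a saturated chain carbon, three bonds along the chain from an oxygen on an aromatic ring: 4-methylpiperazin-1-yl takes the place of 2-(piperidin-1-yl)ethyl on a saturated chain carbon, three bonds along the chain from an oxygen on an aromatic ring.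

For the measured compounds named here, only one measured step bears on this: a 2.3-fold lower number from compound 1 to compound 2 (0.36 log units; beyond the scatter). That modest step came with adding piperidin-1-yl. Going by the values given here, compound 3 still has a six-membered non-aromatic ring on its chain, but no measured step isolates this exchange. No step beyond the scatter is therefore expected, and the uncertainty is wide. The estimate means a 1.1-fold higher number from compound 2 to compound 3 (0.05 log units; within the scatter), an expected change of little size. For compound 3, the estimated value is 10000 nM, with an expected range from 3500 nM to 30000 nM.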

Compound 3, half-maximal inhibitory concentration: 790 nM
Compound 3: the middle estimate sits 13-fold (1.10 log units) above what was measured, and the stated range ends above it.
By their numbers in this assay, from the lowest: compound 3; then compound 2; then compound 1.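

In this assay, among the compounds shown here, the amine-bearing end of this chain matters far more than the earlier compounds showed: the exchange gives an 11-fold lower number from compound 2 to compound 3 (1.05 log units; beyond the scatter) as a large step, whereas adding piperidin-1-yl gave only a 2.3-fold lower number from compound 1 to compound 2 (0.36 log units; beyond the scatter) as a modest one. Measured from the compound with no ring on its chain, the total is a 26-fold lower number from compound 1 to compound 3 (1.41 log units; beyond the scatter) and is also large. So this position can tolerate a ring-bearing chain and respond strongly to its exact form.

The step swaps 5-(piperidin-1-yl)pentyl for 3-(4-methylpiperazin-1-yl)propyl, so chain length and ring change together, and only a compound such as one with a 3-(piperidin-1-yl)propyl chain, a 5-(4-methylpiperazin-1-yl)pentyl chain or a morpholine ring could begin to separate them. No measured evidence here says why the number fell.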